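Removing the guanidine-bearing side chain: expected drop in activity

A few compounds are considered here, and "the series" means these few. Any claim that something is new, unique, unknown or untested is made for them only; others in the source may bear on it.

Measured so far:
- compound 1 `C[C@H](NC(=O)CN(c1nc(Cl)nc2c1ncn2C1CCCCO1)C1CC1)C(=O)OCc1ccccc1`: 25.3% 
- compound 2 `N=C(N)NCCC[C@H](NC(=O)CN(c1nc(Cl)nc2c1ncn2C1CCCCO1)C1CC1)C(=O)OCc1ccccc1`: 50.1% 

In a functional assay on the whole organism with Mus musculus as the target, with a stated time of 90 min, at a dose of 3 umol/kg by the oral route (on this read-out lower numbers stand for a weaker effect and higher numbers for a stronger effect at the one dose given), compound 2 stands highest of the two numbers, with compound 1 the nearest and lower. Among the compounds with values here, the one step that bears here is a number 24.8 percentage points higher from compound 1 to compound 2 (beyond the scatter), where adding the group of 6 heavy atoms raised the read-out. Compound 3 `O=C(CN(c1nc(Cl)nc2c1ncn2C1CCCCO1)C1CC1)NCC(=O)OCc1ccccc1` goes the other way: a hydrogen atom in place of a group of 7 heavy atoms (4 carbon, 3 nitrogen; no ring), on a saturated chain carbon bound to an amide-type nitrogen and a carbonyl carbon. Since that earlier step was beyond the scatter, the change to compound 3 is expected to lower the number, and a number 32.1 percentage points lower from compound 2 to compound 3 (beyond the scatter) is the estimated step. Compound 3 is thus expected to give 18%, between 3% and 38%.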

Compound 3, a percentage reported as activity, at one dose (the size of the read-out at that dose, not a potency): 20.3%
Beside the measured number, compound 3's estimate is 2.3 percentage points below it, and the stated range covers the measured number.
By their numbers in this assay, from the lowest: compounds 3 and 1 (each within the scatter of the next); then compound 2.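

In this assay, hydrogen in place of the guanidine-bearing chain gives a number 29.8 percentage points lower from compound 2 to compound 3 (beyond the scatter) while hydrogen in place of methyl at the same carbon gives a number 5 percentage points lower from compound 1 to compound 3 (within the scatter) and so leaves the two small compounds level. At this carbon, then, the read-out rises only with the guanidine-bearing chain; methyl adds nothing that can be told from hydrogen. No measurement shown here accounts for this difference.

As far as these compounds go, whether a chain ending in an amine or a carboxylic acid at this carbon would match compound 2 stays open. So does whether a plain longer chain, without the guanidine, would do the same.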